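The source may report more compounds than this note shows. Statements on the series, on what has been measured and on what is new or still open speak of the compounds shown alone.

Values in a functional assay on the whole organism for inhibition, with Cavia porcellus as the target; a lower number here means that less compound is needed, a higher number that more compound is needed for the effect:
- compound 1 `COc1ccccc1OCC1SCCN1C(=O)CNC(C)=O`: 40 mg/kg
- compound 2 `CCOC(=O)CC(=O)N1CCSC1COc1ccccc1O`: 20 mg/kg
- compound 3 `CCN(CC)CCNC(=O)CC(=O)N1CCSC1COc1ccccc1OC`: 56 mg/kg

Compound 3 has the highest of the three numbers in this assay. Its gap to compound 1 lies within the scatter, while its gap to compound 2 lies beyond it.

Compound 4 `COc1ccccc1OCC1SCCN1C(=O)CC(=O)NCc1ccncc1` follows from compound 3 by one change: pyridin-4-yl in place of (diethylamino)methyl on a saturated chain carbon bound to an amide-type nitrogen. This puts pyridin-4-yl in place of (diethylamino)methyl on a saturated chain carbon bound to an amide-type nitrogen.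

Within the data shown here, no measured pair differs in one place only, so the only guide is the spread of the three values. The expected change is modest, towards a lower number and not beyond the scatter: a 1.6-fold lower number from compound 3 to compound 4 (0.20 log units; within the scatter). For compound 4 the estimated value is 35 mg/kg, with an expected range of 14 mg/kg to 90 mg/kg.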

Compound 4, dose for half-maximal effect: 23 mg/kg
Estimate against measurement, compound 4: 1.5-fold (0.18 log units) above; measured number inside the range.
By their numbers in this assay, from the lowest: compounds 2, 4, 1 and 3 (each within the scatter of the next, the first and the last beyond it).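

In this assay, among these compounds, the first comparison that differs in one place gives a 2.4-fold lower number from compound 3 to compound 4 (0.39 log units; beyond the scatter), so the group on a saturated chain carbon bound to an amide-type nitrogen does affect the dose needed. The change keeps the heavy-atom and hydrogen-bond counts of the leaving group but brings in a six-membered aromatic ring. Nothing available here accounts for the step.

From the compounds shown here alone, whether the ring nitrogen of pyridin-4-yl matters stays open, and phenyl in this place would test that. Going by these compounds, the effect of a longer chain, such as 2-(pyridin-4-yl)ethyl, also stays open.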